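The source may report more compounds than this note shows. Statements on the series, on what has been measured and on what is new or still open speak of the compounds shown alone.

Measured in an assay on isolated protein for displacement of a labelled ligand from metabotropic glutamate receptor 5 (Homo sapiens), with a stated time of 60 min, tested at 1 uM; a lower number here means less inhibition, a higher number more inhibition at the concentration tested (going by the name of the read-out):
- compound 1 `COc1ccc(S(=O)(=O)c2cnc3ccc(F)cc3c2N2CCC(C)CC2)cc1`: 85%
- compound 2 `CC1CCN(c2c(S(=O)(=O)c3cccc(F)c3)cnc3ccc(F)cc23)CC1`: 76%
- compound 3 `CC1CCN(c2c(S(=O)(=O)c3ccccc3)cnc3ccc(F)cc23)CC1`: 40%

Compound 3 stands lowest of the three, with a number 45 percentage points lower from compound 1 to compound 3 (beyond the scatter) and a number 36 percentage points lower from compound 2 to compound 3 (beyond the scatter) both beyond the scatter, while a number 9 percentage points lower from compound 1 to compound 2 (within the scatter) is within it. Compound 4 `Cc1ccc(S(=O)(=O)c2cnc3ccc(F)cc3c2N2CCC(C)CC2)cc1Cl` is not yet measured; the change from compound 3 is 3-chloro-4-methylphenyl in place of phenyl on a sulfonyl sulfur. The two steps that bear on it are those that strip a substituent from the phenyl on the sulfonyl sulfur, each a large loss; adding substituents back is therefore expected to reverse that, giving a large gain in this assay. For compound 4 the expected step is a number 35 percentage points higher from compound 3 to compound 4 (beyond the scatter). Compound 4 is thus estimated at 75%, within 55% to 92%.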

Compound 4, a percentage reported as inhibition, at one concentration (the size of the read-out at that concentration, not a potency): 91%
Compound 4: the middle estimate sits 16 percentage points below what was measured; the measured number falls inside the stated range.
By their numbers in this assay, from the lowest: compound 3; then compounds 2, 1 and 4 (each within the scatter of the next, the first and the last beyond it).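

In this assay, 3-chloro-4-methylphenyl on the sulfonyl sulfur gives a number 51 percentage points higher from compound 3 to compound 4 (beyond the scatter), and it also separates from a single fluoro substituent, with a number 15 percentage points higher from compound 2 to compound 4 (beyond the scatter). Against 4-methoxyphenyl, the change gives a number 6 percentage points higher from compound 1 to compound 4 (within the scatter), so two quite different substituted phenyl groups cannot be told apart at this position. No measurement available here accounts for these steps. Open, as far as these compounds go, is what 3-chlorophenyl or 4-methylphenyl alone would give, and so how the gain divides between chloro and methyl. Also open, from the compounds shown here alone, is whether an amine or a carboxylic acid on this phenyl would keep the number.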